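Swapping bromo for chloro on the core of compound 1

A few compounds are considered here, and "the series" means these few. Any claim that something is new, unique, unknown or untested is made for them only; others in the source may bear on it.

Of the compounds shown here, three have been tested in a functional assay on MCF7 cells (Homo sapiens) for antiproliferative activity, read by colorimetric assay and sulforhodamine B assay, with a stated time of 3 days; a lower number here means a stronger inhibitor, a higher number a weaker inhibitor. Compound 1 `CCOC(=O)Cn1cnc2c(Br)ncnc21` gives 14100 nM. Compound 2 `CCOC(=O)Cn1cc(F)c(=O)[nH]c1=O` gives 25200 nM, a number that lies within the usual scatter of the number for compound 1. Compound 3 `CCOC(=O)Cn1cnc2ncnc(Cl)c21` gives 49800 nM, and its gap from compound 1 is larger than the scatter, so compound 1 holds the lower number of that pair. The next compound, compound 4 `CCOC(=O)Cn1cnc2c(Cl)ncnc21`, keeps the core of compound 1 and differs from it in one place: chloro in place of bromo on an aromatic carbon. One halogen atom leaves and another enters, with no change in ring count, donors, acceptors or charge. No comparable exchange has been measured here, so the size of the step is uncertain. The step from compound 1 to compound 4 in this assay is expected to be small, a 1.3-fold higher number from compound 1 to compound 4 (0.11 log units; within the scatter), not beyond the scatter. Compound 4 is therefore estimated at 18000 nM, with a likely range from 7000 nM to 50000 nM.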

Compound 4, half-maximal inhibitory concentration: 35100 nM
Compound 4: middle estimate off by 2.0-fold (0.29 log units), on the low side, and the stated range covers the measured number.
By their numbers in this assay, from the lowest: compounds 1, 2, 4 and 3 (each within the scatter of the next, the first and the last beyond it).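

In this assay, among the compounds shown here, chloro in place of bromo on this aromatic carbon gives a 2.5-fold higher number from compound 1 to compound 4 (0.40 log units; beyond the scatter), the first step here between compounds that differ in one place. It shows that the two halogens are not interchangeable at this position, even though ring count, donors, acceptors and charge stay the same. Nothing available here accounts for the size of this step. 

Still open, going by these compounds, is how an iodo, a fluoro or an amine would fare on this same carbon. On these data alone, it is also open whether the step between bromo and chloro would hold with a carboxylic acid in place of the ester.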